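The source may report more compounds than this note shows. Statements on the series, on what has been measured and on what is new or still open speak of the compounds shown alone.

Compound 3 `CCOC(=O)CCCCCOc1cccc(CN(C(=O)c2ccc(-c3cccnc3)cc2)C(C)C)c1` stands at the edge of what an ADME assay on Raji cells (Homo sapiens) for cytotoxicity, read by CellTiter-Glo and resazurin assay, with a stated time of 72 h (on this read-out lower numbers stand for an effect already at smaller amounts and higher numbers for an effect only at larger amounts of compound), can report: in this assay compound 3 gives > 26000 nM, a limit rather than a number. Compound 1 `CCOC(=O)CCCCCOc1cccc(CN(C(=O)c2ccc(-c3cccc4ccccc34)cc2)C(C)C)c1` gives > 26000 nM in this assay, also a limit. Compound 2 `CCOC(=O)CCCCCOc1cccc(CN(C(=O)c2ccc(-c3cccc(-c4ccccc4)c3)cc2)C(C)C)c1` gives > 26000 nM in this assay, again a limit. All three values rest on a single line, (the limit of > 26000 nM in this assay, at which 3 of the 3 values shown sit). The change to compound 4 `CCOC(=O)CCCCCOc1cccc(CN(C(=O)c2ccc(-c3cccc(OC(C)C)c3)cc2)C(C)C)c1` is 3-isopropoxyphenyl in place of pyridin-3-yl on an aromatic carbon. Within the data shown here, the steps that bear on it, a step that the two limits leave unreadable from compound 1 to compound 3, a step that the two limits leave unreadable from compound 2 to compound 3 and a step that the two limits leave unreadable from compound 1 to compound 2, have no readable size, so no step beyond the scatter can be read from them. Compound 4 is therefore expected to give about 30000 nM, within 12000 nM to 120000 nM, most likely reported again as a limit. The expected step is estimated as a step that the limit leaves unreadable from compound 3 to compound 4.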

Compound 4, half-maximal effective concentration: > 26000 nM
Compound 4: no number, only a limit; the forecaster's own chance of this, stated with the estimate: 85%; the middle value lies beyond the limit too.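

In this assay, among these compounds, compound 4 gives > 26000 nM, again a limit, so no step linking it to compound 1, compound 2 or compound 3 can be read. The compounds shown leave open whether any of these groups changes the read-out at all, as all sit at one edge: the limit of > 26000 nM in this assay, at which 4 of the 4 values shown sit.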